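Moving the methoxy group around the sulfonyl pyridine

The source may report more compounds than this note shows. Statements on the series, on what has been measured and on what is new or still open speak of the compounds shown alone.

Measured compounds:
- Compound 1 `CNCc1cn(S(=O)(=O)c2cccs2)c(-c2cccnc2F)c1F`: 98%
- Compound 2 `CNCc1cn(S(=O)(=O)c2cccc(OC)n2)c(-c2cccnc2F)c1F`: 98%

In a functional assay on the whole organism (strain Jcl:Sprague-Dawley) for inhibition, with Rattus norvegicus as the target, with stated times of 3 min and 3 h, at a dose of 1 mg/kg by the intravenous route (on this read-out lower numbers stand for less inhibition and higher numbers for more inhibition at the one dose given (going by the name of the read-out)), compound 1 gives 98% and compound 2 gives 98%. For the measured compounds named here, the one measured step, no change at the digits printed from compound 1 to compound 2 (within the scatter), shows that swapping the group on the sulfonyl sulfur left the read-out unchanged. Compound 3 `CNCc1cn(S(=O)(=O)c2cc(OC)ccn2)c(-c2cccnc2F)c1F` is not yet measured; it differs from compound 2 by 4-methoxypyridin-2-yl in place of 6-methoxypyridin-2-yl on a sulfonyl sulfur. Going by the values given here, since the only related step stayed within the scatter, the expected step of a number 2 percentage points lower from compound 2 to compound 3 (within the scatter) is none beyond the scatter. Compound 3 is therefore estimated at 96%, between 85% and 100%.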

Compound 3, a percentage reported as inhibition, in the whole organism at one dose (the size of the read-out at that dose, not a potency): 95%
Estimate against measurement, compound 3: 1 percentage points above; measured number inside the range.
By their numbers in this assay, from the lowest: compounds 3, 1 and 2 (each within the scatter of the next).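

The step of a number 3 percentage points lower from compound 2 to compound 3 (within the scatter) in this assay shows that moving the methoxy group on the pyridine ring does not separate these two compounds at this dose. The step of a number 3 percentage points lower from compound 1 to compound 3 (within the scatter) shows that 4-methoxypyridin-2-yl and thiophen-2-yl on the sulfonyl sulfur also cannot be told apart here. No outside data bear on this result.

The compounds shown leave open whether differences would appear at a lower dose. They also leave open whether a carboxylic acid on the pyridine ring, or a phenyl group on the sulfonyl sulfur, would keep this level.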